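Swapping tert-Butyl for Pentyl on an Aromatic Carbon

This account rests on a few compounds, and the source may have more. Where it says the series, first, only, none or still open, it means among the compounds named here.

In an assay on mitochondria from L6 cells (Rattus norvegicus) for activation, with a stated time of 90 min (a higher number here means that more compound is needed for the effect, a lower number that less compound is needed), two compounds have been measured so far. Compound 1 `Oc1nc2nonc2nc1Nc1ccccc1` gives 66700 nM. Within the data shown here, compound 2 `CC(C)(C)c1ccc(Nc2nc3nonc3nc2O)cc1` gives 3900 nM, the lowest of the two numbers, and the one step that links them, a 17-fold lower number from compound 1 to compound 2 (1.23 log units; beyond the scatter), came with tert-butyl in place of hydrogen on an aromatic carbon. Compound 3 `CCCCCc1ccc(Nc2nc3nonc3nc2O)cc1` has not yet been measured; it differs from compound 2 in one place: pentyl in place of tert-butyl on an aromatic carbon. Among the measured compounds shown here, the single measured step bears on this change only loosely, since it shows how much a tert-butyl group adds over hydrogen, not how pentyl compares with tert-butyl; both groups are plain carbon chains without rings or hydrogen-bonding atoms. A step no larger than the scatter, in either direction, is therefore expected. Compound 3 is expected to give about 3500 nM, within a range from 1200 nM to 10000 nM, which means a step of a 1.1-fold lower number from compound 2 to compound 3 (0.05 log units; within the scatter).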

Compound 3, half-maximal effective concentration: 2400 nM
The estimate for compound 3 lay 1.5-fold (0.16 log units) above the measured number; the measured number falls inside the stated range.
By their numbers in this assay, from the lowest: compounds 3 and 2 (each within the scatter of the next); then compound 1.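

At this aromatic carbon, replacing tert-butyl with pentyl gives a 1.6-fold lower number from compound 2 to compound 3 (0.21 log units; within the scatter) in this assay, so these two groups cannot be told apart here, even though tert-butyl has 4 heavy atoms and pentyl has 5. The comparison with hydrogen also gives a 28-fold lower number from compound 1 to compound 3 (1.44 log units; beyond the scatter) and thus a large step of the kind seen with tert-butyl. Among these three compounds, then, the large step is not confined to tert-butyl: both carbon groups stand well apart from hydrogen, while their difference from each other stays within the scatter.

On these data alone, it remains open whether a longer chain such as octyl, or an amine or a carboxylic acid at this carbon, would keep the number near those of compound 2 and compound 3. No available evidence explains why the two carbon groups give such similar numbers.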